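The compounds below may be only part of what the source reports. "The series", "measured", "known", "first", "only" and "open" are said of these compounds alone.

Compound 1 `CCc1cc2ccccc2nc1-c1cc(-c2ccccc2)no1` carries an ethyl on the shared core. On these data alone, in a functional assay on PC-3 cells (Homo sapiens) for inhibition, read by MTT assay, with a stated time of 24 h (a higher number here means a weaker inhibitor, a lower number a stronger inhibitor), compound 1 gives only a limit of the assay, > 100000 nM, so its number is unknown. Compound 2 `CCCc1cc2ccccc2nc1-c1cc(-c2ccccc2)no1` differs by methyl in place of hydrogen on a saturated chain carbon, two bonds along the chain from an aromatic carbon, and in this assay compound 2 gives 51300 nM, a step of an at least 1.9-fold lower number from compound 1 to compound 2 (0.28 log units; that floor lies within the scatter). Compound 3 `CCCc1cc2ccccc2nc1-c1cc(-c2ccc(F)cc2)no1` adds fluoro in place of hydrogen on an aromatic carbon, and compound 3 gives 42200 nM, a step of a 1.2-fold lower number from compound 2 to compound 3 (0.08 log units; within the scatter); the difference between the cores of compound 3 and compound 1 is not broken down here. Compound 4 `CCCCc1cc2ccccc2nc1-c1cc(-c2ccc(F)cc2)no1` is not yet measured and differs from compound 3 by methyl in place of hydrogen on a saturated chain carbon, three bonds along the chain from an aromatic carbon, the same kind of change as before, though the place differs: three bonds along the chain rather than two. A step resembling the earlier one is expected, a 1.5-fold lower number from compound 3 to compound 4 (0.18 log units; within the scatter), resting on compound 2 at 51300 nM. For compound 4 the estimate is 28000 nM, between 10000 nM and 80000 nM.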

Compound 4, half-maximal inhibitory concentration: 26300 nM
Beside the measured number, compound 4's estimate is 1.1-fold (0.03 log units) above it, and the stated range covers the measured number.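

Putting methyl in place of hydrogen on the chain gives a 1.6-fold lower number from compound 3 to compound 4 (0.21 log units; within the scatter), so on its own this step does not separate the two compounds. The same change now stands on two cores, and the two results compare as follows: the same change on two cores in this assay, an at least 1.9-fold lower number (0.28 log units; that floor lies within the scatter) from compound 1 to compound 2 and a 1.6-fold lower number (0.21 log units; within the scatter) from compound 3 to compound 4; the limit leaves it open whether they differ The numbers therefore give no sign that the change behaves differently from one core to the other, but they do not show that it carries over at the same size, and compound 1 gives only a limit of the assay: the limit of > 100000 nM in this assay, at which 1 of the 4 values shown sits.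

The compounds shown leave open what a chain longer than butyl would give in this assay. They also leave open what an amine or a carboxylic acid in place of the chain would give.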